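Swapping Methoxy for Chloro on the Aryl Ring

The source may hold more compounds than are shown below. What is called first, only, known or untested is meant among the compounds shown, and "the series" means these compounds.

Compound 1 `COc1ccc(C2CC(c3ccc4ccccc4c3)=NN2C2=NC(=O)/C(=C3\C(=O)Nc4ccccc43)S2)cc1` carries a 4-methoxyphenyl group on the shared core. For the measured compounds named here, in a functional assay on cells (Cancer cell lines, Homo sapiens) for cytotoxicity, read by sulforhodamine B assay, with a stated time of 48 h (a lower number here means a stronger inhibitor of growth, a higher number a weaker inhibitor of growth), compound 1 gives 12600 nM, the higher of the two numbers measured so far. Compound 2 `COc1ccc(C2CC(c3ccc4ccccc4c3)=NN2C2=NC(=O)/C(=C3\C(=O)Nc4ccc(Br)cc43)S2)cc1` differs from it only by bromo in place of hydrogen on an aromatic carbon, and in this assay compound 2 gives 210 nM; that single change produced a 60-fold lower number from compound 1 to compound 2 (1.78 log units; beyond the scatter). Compound 3 `O=C1N=C(N2N=C(c3ccc4ccccc4c3)CC2c2ccc(Cl)cc2)S/C1=C1/C(=O)Nc2ccccc21` has not yet been measured. It differs from compound 1 by chloro in place of methoxy on an aromatic carbon. Going by the values given here, no measured step touches this change: the one step in hand is a different substitution at a different place, so it shows that a small change can move the number greatly but says nothing about the direction here. A modest step is therefore expected, a 1.6-fold lower number from compound 1 to compound 3 (0.20 log units; within the scatter). Compound 3 is estimated to give about 8000 nM in this assay, within a range from 2000 nM to 30000 nM.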

Compound 3, concentration for total growth inhibition: 27300 nM
Compound 3: middle estimate off by 3.4-fold (0.53 log units), on the low side; measured number inside the range.
By their numbers in this assay, from the lowest: compound 2; then compound 1; then compound 3.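

In this assay, this place on the aryl ring proves sensitive to the swap of 4-methoxyphenyl to 4-chlorophenyl, which gives a 2.2-fold higher number from compound 1 to compound 3 (0.34 log units; beyond the scatter) and so a weaker inhibitor of growth. This step is much smaller than a 60-fold lower number from compound 1 to compound 2 (1.78 log units; beyond the scatter) and runs the opposite way, so the two changes on the shared core do not act alike, though each rests on a single pair. No measurement available here explains why chloro reads worse than methoxy at this place.

From the compounds shown here alone, it remains open whether a hydroxyl, a fluoro, a dimethylamino or a longer ether chain such as ethoxy would read better or worse than methoxy at this place. Going by these compounds, it is also open whether the bromo change seen in compound 2 would bring a similar gain on the 4-chlorophenyl compound.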